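Replacing Fluoro with Methoxy in Compound 3

The source may hold more compounds than are shown below. What is called first, only, known or untested is meant among the compounds shown, and "the series" means these compounds.

Compound 2 `COc1ccc(CS(=O)(=O)/C=C/c2ccc(F)cc2OC)cc1` gives 15000 nM in a functional assay on BT-20 cells (Homo sapiens) for antiproliferative activity, read by trypan blue exclusion; on this read-out higher numbers stand for weaker inhibition and lower numbers for stronger inhibition. Of the two numbers recorded, compound 2 stands highest; its nearest neighbour is compound 1 `COc1ccc(CS(=O)(=O)/C=C/c2ccccc2OC)cc1`, which in this assay gives 5000 nM. Compound 3 `COc1ccc(CS(=O)(=O)/C=C/c2ccc(OC)cc2OC)cc1` differs from compound 2 by methoxy in place of fluoro on an aromatic carbon. Going by the values given here, the only measured step that touches this position is a 3.0-fold higher number from compound 1 to compound 2 (0.48 log units; beyond the scatter), which describes fluoro entering where hydrogen stood and shows that a change at this site moves the number by a modest amount beyond the scatter. Among the compounds with values here, no measured pair shows what a methoxy group at this place does, so the direction of the step from compound 2 to compound 3 cannot be read from any measured step, and the size is expected to be small relative to the scatter or modest at most. Compound 3 is therefore expected to give a number near that of compound 2, with a broad range on either side. The estimate for compound 3 in this assay is 10000 nM, between 3000 nM and 40000 nM, which means an expected step of a 1.5-fold lower number from compound 2 to compound 3 (0.18 log units; within the scatter).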

Compound 3, half-maximal inhibitory concentration: > 20000 nM
Compound 3 ended at the assay's limit (the forecaster's own chance of this, stated with the estimate: 20%); at least 2.0-fold (0.30 log units) between middle value and limit.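

In this assay compound 3 gives no number, only a limit of the assay: the limit of > 20000 nM in this assay, at which 1 of the 3 values shown sits. Even so, the result adds a second group to the picture at this position, for until now only fluoro had been seen there, and methoxy in place of hydrogen also moves the read-out towards weaker inhibition, with an at least 4.0-fold higher number from compound 1 to compound 3 (0.60 log units; beyond the scatter); among the three compounds shown, both groups tried on this aromatic carbon give a higher number than hydrogen, and none goes against this. The comparison of the two groups with each other is less firm, since an at least 1.3-fold higher number from compound 2 to compound 3 (0.12 log units; that floor lies within the scatter) is only a floor, which leaves methoxy and fluoro unordered for now.

The compounds shown leave open how far compound 3 really lies past its limit, and so whether methoxy is any worse than fluoro on this carbon. They also leave open whether an amine, a carboxylic acid or a longer chain such as ethoxy in this position would follow the same direction, or would instead give a lower number than compound 1, at 5000 nM.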